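The source may hold more compounds than are shown below. What is called first, only, known or untested is meant among the compounds shown, and "the series" means these compounds.

Measured in a functional assay on MCF7 cells (Homo sapiens) for inhibition, read by fluorescence, with a stated time of 72 h; a higher number here means a weaker inhibitor, a lower number a stronger inhibitor:
- Compound 1 `CCn1cnc2c(NC(=N)N)nc(N)nc21`: 54300 nM
- Compound 2 `CC(C)n1cnc2c(N)nc(N)nc21`: > 100000 nM

Compound 2 stands at > 100000 nM, which is a limit of the assay and not a number. Compound 3 `CCn1cnc2c(N)nc(N)nc21` differs from compound 2 by one small change, isopropyl to ethyl: hydrogen in place of methyl on a saturated chain carbon bound to an aromatic nitrogen and a saturated chain carbon. Among the compounds with values here, no measured pair shows this change, so the expectation is cautious: in this assay, no step beyond the scatter, and no firm direction. The estimated size of the change is a number no higher from compound 2 to compound 3 (the limit leaves the size open). For compound 3 the expected value is 100000 nM, within an estimated range of 45000 nM to 220000 nM.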

Compound 3, half-maximal inhibitory concentration: > 100000 nM
Compound 3 ended at the assay's limit; the forecaster's own chance of this, stated with the estimate: 60%; the middle value lies on the limit itself.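

In this assay compound 3 gives a limit, as compound 2 does, so the step for isopropyl to ethyl cannot be read. Putting a hydrogen atom in place of a group of 3 heavy atoms, on a nitrogen on an aromatic ring, gives an at least 1.8-fold higher number from compound 1 to compound 3 (0.26 log units; that floor lies within the scatter), so this change is not yet shown to matter. The size of that step stays unknown because the values end at a limit: the limit of > 100000 nM in this assay, at which 2 of the 3 values shown sit.

Going by these compounds, whether a longer chain in place of ethyl, or a carboxylic acid in place of that group of 3 heavy atoms, would give a value clear of the limit stays open.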